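The compounds below may be only part of what the source reports. "The series", "measured", "known", "first", "only" and "open" are said of these compounds alone.

In a functional assay on A549 cells (Homo sapiens) for antiproliferative activity, with a stated time of 72 h (a lower number here means a stronger inhibitor, a higher number a weaker inhibitor), compound 2 (`O=C(COc1ccc(CNC2CC=C(c3c[nH]c4ccc(F)cc34)CC2)c(F)c1)NO`) gives 304 nM and compound 1 (`O=C(COc1ccc(CNC2CC=C(c3c[nH]c4cccc(F)c34)CC2)c(F)c1)NO`) gives 203 nM while compound 3 (`Cc1[nH]c2ccccc2c1C1=CCC(NCc2ccc(OCC(=O)NO)cc2)CC1`) gives 187 nM and these three values all lie within the scatter of one another. Compound 4 (`O=C(COc1ccc(CNC2CC=C(c3c[nH]c4ccccc34)CC2)c(F)c1)NO`) differs from compound 2 in one place (hydrogen in place of fluoro on an aromatic carbon): hydrogen in place of fluoro on an aromatic carbon, turning 5-fluoro-1H-indol-3-yl into 1H-indol-3-yl. The closest measured evidence is a shift of that fluoro, not its removal: a 1.5-fold higher number from compound 1 to compound 2 (0.18 log units; within the scatter) stays within the scatter. Compound 3 differs from compound 4 in more than one place, so it offers no direct comparison. In this assay the expected step is therefore a 1.4-fold lower number from compound 2 to compound 4 (0.14 log units; within the scatter) and no larger than the scatter. Compound 4 is expected at 220 nM with an estimated range of 110 nM to 440 nM once it is measured.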

Compound 4, half-maximal inhibitory concentration: 278 nM
For compound 4 the middle estimate is 1.3-fold (0.10 log units) below the measured one, and the stated range covers the measured number.
By their numbers in this assay, from the lowest: compounds 3, 1, 4 and 2 (each within the scatter of the next).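

In this assay taking the fluoro away altogether gives a 1.1-fold lower number from compound 2 to compound 4 (0.04 log units; within the scatter) and a 1.4-fold higher number from compound 1 to compound 4 (0.14 log units; within the scatter), so 1H-indol-3-yl cannot be told apart from either fluorinated indole. The earlier compounds shown here showed only a shift of the fluoro, whereas these steps compare its presence with its absence. No measurement shown explains this result. On these data alone, whether a larger group on this aromatic carbon, such as methoxy or a carboxylic acid, would move the number beyond the scatter remains open.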